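The source may report more compounds than this note shows. Statements on the series, on what has been measured and on what is new or still open speak of the compounds shown alone.

Measured so far in an ADME assay on L6 cells (Rattus norvegicus) for cytotoxicity; a lower number here means a stronger inhibitor, a higher number a weaker inhibitor:
- Compound 1 `Cc1ccc(S(=O)(=O)N2c3ccccc3CCC2C)cc1`: 4900 nM
- Compound 2 `CC1CCc2ccccc2N1S(=O)(=O)c1ccc([N+](=O)[O-])cc1`: 248000 nM

Going by the values given here, compound 2 stands at the top of these two numbers at 248000 nM, and compound 1 is its only neighbour. Compound 3 `CC(=O)Nc1ccc(S(=O)(=O)N2c3ccccc3CCC2C)cc1` keeps the shared core and carries acetamido in place of nitro on an aromatic carbon, para to a large group: acetamido in place of nitro on an aromatic carbon. Among the compounds with values here, only one measured step bears on this change, and it does so indirectly. That step, with nitro in place of methyl at this carbon, is a 51-fold higher number from compound 1 to compound 2 (1.70 log units; beyond the scatter), which is large and beyond the scatter. Within the data shown here, no measured compound carries acetamido, so the data do not show where this group falls. Among the measured compounds shown here, still, compound 1 shows through a 51-fold higher number from compound 1 to compound 2 (1.70 log units; beyond the scatter) that a change at this carbon can move this assay widely, and that the one compound without nitro has the lower number. A sizeable step to a lower number is therefore expected, though one smaller than the measured step. The expected change is a 6.2-fold lower number from compound 2 to compound 3 (0.79 log units; beyond the scatter). For compound 3 the estimated value is 40000 nM, with an expected range from 9000 nM to 180000 nM.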

Compound 3, half-maximal inhibitory concentration: 52000 nM
Compound 3: middle estimate off by 1.3-fold (0.11 log units), on the low side; the measured number falls inside the stated range.
By their numbers in this assay, from the lowest: compound 1; then compound 3; then compound 2.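

In this assay, the change from nitro to acetamido at this aromatic carbon gives a 4.8-fold lower number from compound 2 to compound 3 (0.68 log units; beyond the scatter) and so shows that the high number of compound 2 does not extend to every group that replaces methyl here. Yet acetamido does not bring the number back to that of compound 1, for the comparison with methyl gives an 11-fold higher number from compound 1 to compound 3 (1.03 log units; beyond the scatter) and shows that a second group, one that shares no atoms count or hydrogen-bond donor count with nitro, also stands well above methyl at this carbon. The three compounds thus rank methyl, acetamido and nitro from the lowest number to the highest, although nothing available gives a reason for this order.

These three compounds leave open where a free amine, a carboxylic acid or a longer acyl chain on the same nitrogen would fall at this carbon, and whether any such group could match or go below the number of compound 1. They also leave open whether the same order of methyl, acetamido and nitro would hold if another part of the shared core were changed.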